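A few compounds are considered here, and "the series" means these few. Any claim that something is new, unique, unknown or untested is made for them only; others in the source may bear on it.

Measured compounds:
compound 1 `CN(Cc1ccc2c(c1)CCCO2)c1nnc(-c2ccc(-c3ccccc3Cl)cc2)o1`: 398 nM
compound 2 `CN(Cc1ccc2nccn2c1)c1nnc(-c2ccc(OC3CCCC3)cc2)o1`: 3980 nM
compound 3 `CNC(=O)c1sc(N2CC3CC2(CNC(=O)c2c[nH]c4ncc(C(F)(F)F)cc24)C3)nc1C(F)(F)F`: 25.1 nM

All three were tested in an assay on isolated protein for inhibition of tyrosine-protein kinase receptor UFO (Homo sapiens), read by LC-MS, with stated times of 30 min and 180 min; on this read-out lower numbers stand for stronger inhibition and higher numbers for weaker inhibition. Compound 3 gives the lowest number of the set: compound 1 sits at a much higher number and compound 2 higher still, and both gaps lie well beyond the scatter. Compound 3 is therefore the most potent of the measured compounds.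

Compound 4 `CNC(=O)c1sc(N2CC3CC2(CNC(=O)c2c[nH]c4ncccc24)C3)nc1C(F)(F)F` has not yet been measured. It differs from compound 3 in a single place: hydrogen in place of trifluoromethyl on an aromatic carbon. Within the data shown here, no measured pair shows this change, so no step of known size can be set beside it. The expectation rests on compound 3 alone, whose number in this assay is 25.1 nM. Removing the trifluoromethyl is expected to cost some potency, a step of a 2.5-fold higher number from compound 3 to compound 4 (0.40 log units; beyond the scatter) toward a higher number, modest in size but likely beyond the scatter. Compound 4 is estimated at 63 nM, with a range from 20 nM to 200 nM.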

Compound 4, half-maximal inhibitory concentration in the tyrosine-protein kinase receptor UFO assay: 10 nM
The estimate for compound 4 lay 6.3-fold (0.80 log units) above the measured number, and the stated range ends above it.
By their numbers in the tyrosine-protein kinase receptor UFO assay, from the lowest: compound 4; then compound 3; then compound 1; then compound 2.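

In the tyrosine-protein kinase receptor UFO assay hydrogen in place of trifluoromethyl on this aromatic carbon gives a 2.5-fold lower number from compound 3 to compound 4 (0.40 log units; beyond the scatter) so the trifluoromethyl is not required for potency at this position. Among these compounds, this is the first step of known size, as the earlier compounds held no pair differing in one place. The same change moves the number in a physicochemical assay for lipophilicity, at pH 7.4 (a higher number here means a more lipophilic compound, a lower number a more polar compound), down as well, from compound 3 at 4.2 to compound 4 at 3.1 so potency rises here while lipophilicity falls: the measured distribution coefficient of compound 3, 4.2, and of compound 4, 3.1, a number 1.10 log units lower (beyond the scatter)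

One pair cannot tell whether the two shifts are linked. Fluorine, a nitrile or a methoxy group on this carbon would show whether hydrogen itself is preferred or whether other small groups serve as well.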